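Swapping the aryl group on a pyrazole urea TRPV1 antagonist

The source may hold more compounds than are shown below. What is called first, only, known or untested is meant among the compounds shown, and "the series" means these compounds.

Measured so far:
compound 1 `Cn1ncc2c(NC(=O)NCc3cc(C(C)(C)C)nn3-c3ccc(Cl)cc3)cccc21` 9.5 nM
compound 2 `Cn1ncc2c(NC(=O)NCc3cc(C(C)(C)C)nn3-c3ccc(C(C)(C)C)cc3)cccc21` 46.3 nM

In an assay on CHO-K1 cells for antagonist activity at transient receptor potential cation channel subfamily V member 1 (Homo sapiens), read by FLIPR and calcium flux, with a stated time of 6 min (a higher number here means a weaker inhibitor, a lower number a stronger inhibitor), compound 2 gives the higher of the two numbers; the step of a 4.9-fold higher number from compound 1 to compound 2 (0.69 log units; beyond the scatter) is the only one in hand, and it puts tert-butyl in place of chloro on the aromatic carbon. Compound 3 `Cn1ncc2c(NC(=O)NCc3cc(C(C)(C)C)nn3-c3ccc(F)c(F)c3)cccc21` carries the change (3,4-difluorophenyl in place of 4-(tert-butyl)phenyl on an aromatic nitrogen). Since a smaller halogenated ring in compound 1 gave the lower number, a return toward that end is expected: the estimated step is a 3.9-fold lower number from compound 2 to compound 3 (0.59 log units; beyond the scatter), a drop in this assay, and compound 3 is expected near 12 nM, between 4 nM and 40 nM.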

Compound 3, inhibition constant: 1 nM
Estimate against measurement, compound 3: 12-fold (1.08 log units) above, and the stated range ends above it.
By their numbers in this assay, from the lowest: compound 3; then compound 1; then compound 2.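

Changing the aryl group on the aromatic nitrogen moves the result in this assay much further than the earlier swap of chloro for tert-butyl did: 3,4-difluorophenyl gives a 46-fold lower number from compound 2 to compound 3 (1.67 log units; beyond the scatter) and, set against 4-chlorophenyl, still gives a 9.5-fold lower number from compound 1 to compound 3 (0.98 log units; beyond the scatter) beyond the scatter. This position therefore separates even two halogenated rings, and compound 3 has the lowest number of the three. Nothing available explains why this ring gives the lower number. Still open, as far as these compounds go, is how a single fluorine, a nitrile or a methoxy group on this phenyl ring would compare.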